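This account rests on a few compounds, and the source may have more. Where it says the series, first, only, none or still open, it means among the compounds named here.

Of the compounds shown here, three have been measured in an assay on Jurkat cells for displacement of a labelled ligand from C-X-C chemokine receptor type 4 (Homo sapiens), tested at 10 uM (a lower number here means less inhibition, a higher number more inhibition at the concentration tested (going by the name of the read-out)), and a fourth awaits measurement. Compound 1 `C[C@@H](NC(=O)[C@H](CCCNC(=N)N)NC(=O)c1ccc(CN(Cc2ccncc2)Cc2ccc(F)cc2)cc1)c1cccc2ccccc12` gives 12% in this assay. Compound 2 `C[C@@H](NC(=O)[C@H](CCCNC(=N)N)NC(=O)c1ccc(CN(Cc2ccncc2)C(=O)c2ccc(F)cc2)cc1)c1cccc2ccccc12` differs from it by (4-fluorophenyl)carbonyl in place of 4-fluorobenzyl on an amine nitrogen, and in this assay compound 2 gives 6%, so that the step is a number 6 percentage points lower from compound 1 to compound 2 (within the scatter). Compound 3 `C[C@H](NC(=O)[C@H](CCCNC(=N)N)NC(=O)c1ccc(CN(Cc2ccc(F)cc2)Cc2ccccn2)cc1)c1cccc2ccccc12` has the same atoms as compound 1 joined differently; the difference between the two cores is not broken down here. In this assay compound 3 gives 30%, the highest of the three numbers, with compound 1 and compound 2 both lower by more than the usual scatter.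

Compound 4 `C[C@H](NC(=O)[C@H](CCCNC(=N)N)NC(=O)c1ccc(CN(Cc2ccccn2)C(=O)c2ccc(F)cc2)cc1)c1cccc2ccccc12` is to be measured in this assay. It differs from compound 3 by (4-fluorophenyl)carbonyl in place of 4-fluorobenzyl on an amine nitrogen, the same change that separates compound 1 from compound 2, made at an amine nitrogen whose other neighbours are described in the same words in both cases. Among the four compounds this change occurs twice in all, and the one measured instance is small, within the scatter. For the measured compounds named here, the step from compound 3 to compound 4 is therefore expected to be of similar size, a number 6 percentage points lower from compound 3 to compound 4 (within the scatter), resting on the single measured step of a number 6 percentage points lower from compound 1 to compound 2 (within the scatter). On that basis compound 4 is estimated to give 24% in this assay, with a range from 10% to 38% expected. The range reaches no lower because compound 3 gives 30%, which leaves room for a modest fall.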

Compound 4, a percentage reported as inhibition, at one concentration (the size of the read-out at that concentration, not a potency): 36%
Compound 4: middle estimate off by 12 percentage points, on the low side; measured number inside the range.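

On the core of compound 3, the change from 4-fluorobenzyl to (4-fluorophenyl)carbonyl on the amine nitrogen in this assay comes to a number 6 percentage points higher from compound 3 to compound 4 (within the scatter). The two measured instances of the change point in opposite directions, but the gap between them is no larger than such steps can show by scatter alone, so the data give no sign that the core alters its outcome: the same change on two cores in this assay, a number 6 percentage points lower (within the scatter) from compound 1 to compound 2 and a number 6 percentage points higher (within the scatter) from compound 3 to compound 4, 12 percentage points apart, within the scatter of two such steps

For the compounds shown here, this shows only that the change left the read-out within the scatter on both of these cores; it does not establish a true rise on one core and a true fall on the other, and it does not show that the change would be as small on any other core or that potency is unchanged, since each number comes from a single tested concentration.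

The compounds shown leave open how a sulfonyl linkage or a longer chain, such as 2-phenylethyl, would behave on the same amine nitrogen. Going by these compounds alone, they also leave the difference between the two cores unresolved, with no pair here that breaks it down into its separate parts.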